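Replacing the silicon-bound aryl group with benzyl

A few compounds are considered here, and "the series" means these few. Any claim that something is new, unique, unknown or untested is made for them only; others in the source may bear on it.

For the measured compounds named here, compound 3 `C=Cc1ccc([Si](C)(C)COc2cccc(CN(CC)C/C=C/C#CC(C)(C)C)c2)cc1` gives the lowest of the three numbers so far in a functional assay on liver (Sus scrofa) for inhibition of squalene monooxygenase (Homo sapiens), using microsomes (on this read-out higher numbers stand for weaker inhibition and lower numbers for stronger inhibition), with 70 nM. Its nearest neighbour is compound 1 `CCN(C/C=C/C#CC(C)(C)C)Cc1cccc(OC[Si](C)(C)c2ccc(C)cc2)c1`, whose result in this assay is 120 nM; the step of a 1.7-fold lower number from compound 1 to compound 3 (0.23 log units; within the scatter) lies within the scatter, so the two cannot be told apart. Compound 2 `CCN(C/C=C/C#CC(C)(C)C)Cc1cccc(OC[Si](C)(C)c2ccc(S)cc2)c1` stands far off with 8000 nM, and the step of a 110-fold lower number from compound 2 to compound 3 (2.06 log units; beyond the scatter) is large. The step of a 67-fold higher number from compound 1 to compound 2 (1.82 log units; beyond the scatter) is of the same size.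

Compound 4 `CCN(C/C=C/C#CC(C)(C)C)Cc1cccc(OC[Si](C)(C)Cc2ccccc2)c1` differs from compound 3 in one place: benzyl in place of 4-vinylphenyl on a silicon. Going by the values given here, none of the measured steps touches the silicon itself; all three change a substituent on the aromatic ring attached to it. They show that compound 1 with methyl and compound 3 with vinyl on that ring give numbers within the scatter of each other, while compound 2 with sulfanyl gives a far higher number. The change to compound 4 removes the vinyl-bearing ring altogether and puts an unsubstituted benzyl on the silicon, which lies outside what the measured steps cover. A modest weakening is therefore expected, in a 2.9-fold higher number from compound 3 to compound 4 (0.46 log units; beyond the scatter), with wide uncertainty. Compound 4 is estimated at 200 nM, with a range from 50 nM to 800 nM.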

Compound 4, half-maximal inhibitory concentration: 130 nM
Beside the measured number, compound 4's estimate is 1.5-fold (0.19 log units) above it; low and high end bracket the measured number.
By their numbers in this assay, from the lowest: compounds 3, 1 and 4 (each within the scatter of the next); then compound 2.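

Benzyl on the silicon is accepted in this assay as readily as the substituted aryl groups, since neither of these steps leaves the scatter (a 1.9-fold higher number from compound 3 to compound 4 (0.27 log units; within the scatter); a 1.1-fold higher number from compound 1 to compound 4 (0.03 log units; within the scatter)). The earlier compounds shown here varied only a substituent on the aromatic ring, whereas this result shows that the group on the silicon can change from 4-vinylphenyl or 4-methylphenyl to benzyl, which carries neither vinyl nor methyl, without a change that can be read in this assay. Only compound 2 stays well apart (a 62-fold lower number from compound 2 to compound 4 (1.79 log units; beyond the scatter)), and nothing shown gives a reason for any of these results.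

The compounds shown leave open whether a longer chain ending in phenyl, such as 2-phenylethyl, or a group with no aromatic ring, such as cyclohexylmethyl, would also be accepted on the silicon. They also leave open whether a benzyl carrying vinyl, methyl or sulfanyl on its ring would follow the aryl series, and whether an amine or a hydroxyl on the aromatic ring would give a number as high as the sulfanyl group of compound 2 does.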